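The compounds below may be only part of what the source reports. "The series", "measured", "known", "first", "only" and "open" are said of these compounds alone.

The measured compounds:
Compound 1, `C[C@H](CO)Nc1nc(C(=O)NCc2ccc(F)cc2)c(O)c2ncccc12`, in a functional assay on MDA-MB-435 cells (Homo sapiens) for cytotoxicity, read by MTT assay, with a stated time of 72 h (a higher number here means a weaker inhibitor, a lower number a stronger inhibitor), gives > 20000 nM, which is a limit of the assay and not a number.
Compound 2, `N[C@H]1CC[C@H](Nc2c(C(=O)NCc3ccc(Cl)cc3Cl)nc(Br)c3cccnc23)CC1`, gives 5800 nM.
Compound 3, `COC(=O)CNc1c(C(=O)NCc2ccc(F)cc2)nc(Br)c2cccnc12`, gives 10000 nM.

Among the numbers shown, compound 3 stands highest, though its gap to compound 2 lies within the usual scatter of repeated measurements. Compound 4, `NCCCCCCNc1c(C(=O)NCc2ccc(F)cc2)nc(Br)c2cccnc12`, differs from compound 3 in one place: 5-aminopentyl in place of methoxycarbonyl on a saturated chain carbon bound to a nitrogen on an aromatic ring. Among the compounds with values here, no step between two measured compounds is available to calibrate this change, so only a modest shift in this assay is expected, toward a lower number if any, and it may well remain within the scatter. The estimated step is a 2.0-fold lower number from compound 3 to compound 4 (0.30 log units; within the scatter). Compound 4 is accordingly expected to give about 5000 nM, with a range from 1500 nM to 15000 nM.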

Compound 4, half-maximal inhibitory concentration: 6000 nM
Compound 4: middle estimate off by 1.2-fold (0.08 log units), on the low side, within the range that was stated.
By their numbers in this assay, from the lowest: compounds 2, 4 and 3 (each within the scatter of the next). At a limit, above all of these: compound 1.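

In this assay, 5-aminopentyl in place of methoxycarbonyl on a saturated chain carbon bound to a nitrogen on an aromatic ring gives a 1.7-fold lower number from compound 3 to compound 4 (0.22 log units; within the scatter) as the first step readable at this position. The two groups therefore cannot be told apart here, although they differ in charge-free composition and in size as counted. No measurement shown bears on a cause for this step. As far as these compounds go, whether a carboxylic acid in place of methoxycarbonyl would give a step beyond the scatter stays open. So does the effect of a shorter or longer aminoalkyl chain.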